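Isopropylamino in Place of 2-Hydroxyethyl on a Sulfonyl Sulfur

The source may report more compounds than this note shows. Statements on the series, on what has been measured and on what is new or still open speak of the compounds shown alone.

Measured compounds:
compound 1, `CN(C)C(=O)c1cccc(C#Cc2cc(Cl)ccc2OCC(=O)O)c1`, 52 nM
compound 2, `Cc1ccc(S(=O)(=O)CCO)cc1C#Cc1cc(Cl)ccc1OCC(=O)O`, 19 nM
compound 3, `COc1ccc(-c2ccc(C#Cc3cc(Cl)ccc3OCC(=O)O)cc2S(C)(=O)=O)cc1`, 7 nM

All three were tested in an assay on CHO cells for displacement of a labelled ligand from prostaglandin D2 receptor 2 (Homo sapiens), read by scintillation counting; a lower number here means a stronger inhibitor, a higher number a weaker inhibitor. Compound 2 sits in the middle of the three numbers: compound 3 gives the lower value, compound 1 the higher one, and both gaps to compound 2 lie beyond the scatter of the method. The three compounds share a core and differ only in the group attached to the alkyne.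

Compound 4, `Cc1ccc(S(=O)(=O)NC(C)C)cc1C#Cc1cc(Cl)ccc1OCC(=O)O`, has not yet been measured in this assay. It is derived from compound 2 by a single change: isopropylamino in place of 2-hydroxyethyl on a sulfonyl sulfur. The change keeps the sulfonyl on the same aromatic carbon and keeps one hydrogen-bond donor, while exchanging a short hydroxylated chain for a branched amine.

For the measured compounds named here, no measured pair in this set shows what such a swap does on this core, so the expectation rests on compound 2 alone. The step from compound 2 to compound 4 is expected to be small, most likely within the scatter, with a slight lean toward a weaker inhibitor: a 1.5-fold higher number from compound 2 to compound 4 (0.17 log units; within the scatter). Compound 4 is therefore estimated at 28 nM, within a range of 9 nM to 90 nM.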

Compound 4, inhibition constant: 3.4 nM
Beside the measured number, compound 4's estimate is 8.2-fold (0.92 log units) above it, outside the stated range (below it).
By their numbers in this assay, from the lowest: compound 4; then compound 3; then compound 2; then compound 1.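

For the compounds shown here, exchanging 2-hydroxyethyl for isopropylamino on a sulfonyl sulfur is the first change in this set that can be read at a single place, and in this assay it gives a 5.6-fold lower number from compound 2 to compound 4 (0.75 log units; beyond the scatter). The earlier compounds shown here differed in too many places to show this, but this pair shows that the group carried on this sulfur moves the number, and that a branched amine here gives a stronger inhibitor than the short hydroxylated chain. No measurement available here accounts for the gain.

From the compounds shown here alone, this single pair cannot separate the sulfonyl-bound nitrogen from the branching, so it remains open how an unbranched propylamino, a plain amino or an isopropyl bound directly to the sulfur would compare. It also leaves open whether a larger amine such as cyclohexylamino or a tertiary one such as dimethylamino would extend the gain or lose it.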